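Cytotoxicity notes: from compound 2 to compound 3

The source may hold more compounds than are shown below. What is called first, only, known or untested is meant among the compounds shown, and "the series" means these compounds.

Two compounds of the series have been assessed in an ADME assay on HEL cells (Homo sapiens) for cytotoxicity, read by microscopy; on this read-out lower numbers stand for higher toxicity in this test and higher numbers for lower toxicity in this test. Compound 1 `Cc1ccccc1OCCCCCn1ccc(=O)[nH]c1=O` gives a result that is only a limit of the assay, > 100000 nM. Going by the values given here, compound 2 `CC(C)c1ccc(OCCCCCn2ccc(=O)[nH]c2=O)cc1` is the one member with a number, giving 100000 nM in this assay. Compound 2 therefore stands alone as a measured figure among the values shown, the other result being a limit, as seen in the limit of > 100000 nM in this assay, at which 1 of the 2 values shown sits. Among the compounds with values here, no step between two measured compounds can be drawn from these data.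

Compound 3 `O=c1ccn(CCCCCOc2ccccc2)c(=O)[nH]1` is not yet measured. It differs from compound 2 by hydrogen in place of isopropyl on an aromatic carbon. The isopropyl leaves and a hydrogen enters on an aromatic carbon of a six-membered aromatic ring of carbon only.

Within the data shown here, with no measured step available and both results sitting at or beyond the same level, the step from compound 2 to compound 3 in this assay is expected to be no change at the digits printed from compound 2 to compound 3 (within the scatter), that is, none beyond the usual scatter, with any movement more likely toward lower toxicity. Compound 3 is estimated at 100000 nM, in the range 50000 nM to 200000 nM, with a fair chance that only a limit is reported.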

Compound 3, minimum cytotoxic concentration: > 100000 nM
Compound 3 ended at the assay's limit; the forecaster's own chance of this, stated with the estimate: 55%; the middle value sits exactly at the limit.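

In this assay, hydrogen in place of isopropyl on an aromatic carbon, para to a large group, gives a number no lower from compound 2 to compound 3 (the limit leaves the size open). Compound 3 gives > 100000 nM, which is a limit of the assay, so the isopropyl at this place is not required for a result at this level. The step that exchanges methyl for hydrogen cannot be read, and the results so far gather at a single level: the limit of > 100000 nM in this assay, at which 2 of the 3 values shown sit.

The compounds shown leave open whether an amine, a carboxylic acid or a longer chain on the aromatic ring would bring the read-out to a clearly lower number in this assay. Going by these compounds, the actual values of compound 1 and compound 3 also stay open, so no order between them can be given.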